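Compound 3 to compound 4: phenyl to 4-methoxyphenyl

This account rests on a few compounds, and the source may have more. Where it says the series, first, only, none or still open, it means among the compounds named here.

In a functional assay on Ehrlich cells (Mus musculus) for cytotoxicity, read by LDH release, with a stated time of 48 h (on this read-out higher numbers stand for weaker inhibition and lower numbers for stronger inhibition), compound 3 (`Cc1cc(C(=O)c2ccc(F)cc2)ccc1OCC(=O)Nc1nc(-c2ccccc2)cs1`) gives 38600 nM. That number lies within the scatter of the two other measured members of the series: compound 1 (`COc1ccc(-c2csc(NC(=O)COc3ccc(C(=O)c4ccccc4)cc3C)n2)cc1`) gives 28600 nM and compound 2 (`COc1ccc(-c2csc(NC(=O)COc3ccc(C(=O)c4ccc(C)cc4)cc3C)n2)cc1`) gives 20900 nM. Compound 3 is thus not separated from either of them.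

Compound 4 (`COc1ccc(-c2csc(NC(=O)COc3ccc(C(=O)c4ccc(F)cc4)cc3C)n2)cc1`) is still unmeasured. It differs from compound 3 by methoxy in place of hydrogen on an aromatic carbon, para to a large group, which turns phenyl into 4-methoxyphenyl: methoxy in place of hydrogen on an aromatic carbon.

Within the data shown here, the only measured single-place step is a 1.4-fold lower number from compound 1 to compound 2 (0.14 log units; within the scatter), for methyl in place of hydrogen on an aromatic carbon. It involves another group at another place, so it bears on this change only loosely. Among the measured compounds shown here, compound 1 and compound 2 already carry the 4-methoxyphenyl, but each also differs from compound 3 in a second place, and no measured pair isolates the methoxy.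

In this assay the expected step is a 1.4-fold lower number from compound 3 to compound 4 (0.16 log units; within the scatter), a small move to a lower number and none beyond the scatter. For compound 4 the estimated value is 27000 nM, with an expected range from 15000 nM to 46000 nM.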

Compound 4, half-maximal inhibitory concentration: 5800 nM
The estimate for compound 4 lay 4.7-fold (0.67 log units) above the measured number; measured number outside the range, below it.
By their numbers in this assay, from the lowest: compound 4; then compounds 2, 1 and 3 (each within the scatter of the next).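

In this assay the methoxy on the aromatic carbon, para to a large group, produces a clear move with the fluoro held in place (a 6.7-fold lower number from compound 3 to compound 4 (0.82 log units; beyond the scatter)). Among these compounds, this is the first pair to isolate phenyl to 4-methoxyphenyl, and the first step to lie beyond the scatter. With the 4-methoxyphenyl held, the fluoro also separates from its neighbours, both in place of hydrogen (a 4.9-fold lower number from compound 1 to compound 4 (0.69 log units; beyond the scatter)) and in place of methyl (a 3.6-fold lower number from compound 2 to compound 4 (0.56 log units; beyond the scatter)), whereas methyl in place of hydrogen stayed within the scatter (a 1.4-fold lower number from compound 1 to compound 2 (0.14 log units; within the scatter)). Nothing measured here accounts for these steps.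

The compounds shown leave open whether the methoxy step carries over when hydrogen or methyl stands in place of the fluoro, as neither compound 1 nor compound 2 has a phenyl partner in this set. They also leave open how an amine or a longer chain such as ethoxy in place of the methoxy, or chloro in place of the fluoro, would compare with compound 4.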